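The source may hold more compounds than are shown below. What is called first, only, known or untested is meant among the compounds shown, and "the series" means these compounds.

For the measured compounds named here, in a functional assay on MV4-11 cells (Homo sapiens) for inhibition, read by luminescence, with a stated time of 3 days (a lower number here means a stronger inhibitor of growth, a higher number a weaker inhibitor of growth), compound 1 `CC[C@@H]1CC[C@@H](C(=O)N2CCN(C(C)=O)CC2)N1C(=O)C1=C(C(C)C)N2C(=N[C@@](C)(c3ccc(Cl)cc3)[C@H]2c2ccc(Cl)cc2)S1` gives 130 nM, the lower of the two numbers measured so far. Compound 2 `CC(C)C1=C(C(=O)N2[C@H](C)CC[C@H]2C(=O)N2CCN(C)C(C)(C)C2)SC2=N[C@@](C)(c3ccc(Cl)cc3)[C@@H](c3ccc(Cl)cc3)N21` gives 280 nM, and that gap lies beyond the usual scatter. Compound 3 `CC[C@@H]1CC[C@@H](C(=O)N2CCN(C(C)=O)[C@H](C)C2)N1C(=O)C1=C(C(C)C)N2C(=N[C@@](C)(c3ccc(Cl)cc3)[C@H]2c2ccc(Cl)cc2)S1` is compound 1 with one change: methyl in place of hydrogen on a saturated ring carbon, a methyl in place of hydrogen on a saturated ring carbon. Going by the values given here, no measured pair shows what such a change does, so the expectation in this assay is for no shift beyond the scatter, in either direction. The expected step is a 1.1-fold lower number from compound 1 to compound 3 (0.03 log units; within the scatter). For compound 3 the estimated value is 120 nM, with an expected range from 50 nM to 290 nM.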

Compound 3, concentration for 50% growth inhibition: 220 nM
Beside the measured number, compound 3's estimate is 1.8-fold (0.26 log units) below it, within the range that was stated.
By their numbers in this assay, from the lowest: compounds 1, 3 and 2 (each within the scatter of the next, the first and the last beyond it).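

In this assay, the step of a 1.7-fold higher number from compound 1 to compound 3 (0.23 log units; within the scatter) shows that a methyl on this saturated ring carbon, next to the ring nitrogen and next to the ring atom that bears an acetyl group, leaves growth inhibition within the scatter. This carbon of the six-membered ring can therefore carry one extra methyl with no readable shift in this assay. No measurement shown here gives a reason for this result. On these data alone, it remains open whether an ethyl, a hydroxyl or an amine on this carbon would behave the same way, and whether a methyl with the opposite spatial arrangement would do so.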